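The compounds below may be only part of what the source reports. "The series", "measured", "known", "first", "only" and "open" are said of these compounds alone.

Measured compounds:
- compound 1 `CC[C@H](C)[C@H](NC(=O)c1cccc(Cn2ccnc2)c1)C(=O)Nc1nccs1` — 4%
- compound 2 `CC[C@H](C)[C@H](NC(=O)c1cccc(Cn2ccnc2)c1)C(=O)NNS(=O)(=O)c1ccccc1` — 6%

In an assay on HEK293 cells for displacement of a labelled ligand from Type-2 angiotensin II receptor (Homo sapiens), tested at 1 uM (on this read-out lower numbers stand for a weaker effect and higher numbers for a stronger effect at the one concentration tested), compound 1 gives 4%. Within the data shown here, its only measured neighbour is compound 2, and the step of a number 2 percentage points higher from compound 1 to compound 2 (within the scatter) leaves the two inseparable; both read as weak at this concentration.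

Compound 3 `CC[C@H](C)[C@H](NC(=O)c1cccc(Cn2ccnc2)c1)C(=O)NNS(=O)(=O)c1ccc(C)cc1` differs from compound 1 by the change (((4-methylphenyl)sulfonyl)amino in place of 1,3-thiazol-2-yl on an amide-type nitrogen). Among the measured compounds shown here, the one measured step that bears on it is a number 2 percentage points higher from compound 1 to compound 2 (within the scatter), which puts a (phenylsulfonyl)amino in the same place and moved nothing beyond the scatter. Compound 3 carries the same kind of group with one added methyl, so no step beyond the scatter is expected in this assay.

Compound 3 is therefore estimated at 6%, with a range of -4% to 16%, corresponding to an expected step of a number 2 percentage points higher from compound 1 to compound 3 (within the scatter).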

Compound 3, a percentage reported as inhibition, at one concentration (the size of the read-out at that concentration, not a potency): 4%
Estimate against measurement, compound 3: 2 percentage points above; the measured number falls inside the stated range.
By their numbers in this assay, from the lowest: compounds 1, 3 and 2 (each within the scatter of the next).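

In this assay the ((4-methylphenyl)sulfonyl)amino group gives no change at the digits printed from compound 1 to compound 3 (within the scatter) in place of 1,3-thiazol-2-yl on the amide-type nitrogen, so a second sulfonyl-bearing group in this place also produces no step beyond the scatter. The change new to the series, methyl in place of hydrogen on an aromatic carbon, gives a number 2 percentage points lower from compound 2 to compound 3 (within the scatter) and so also leaves the read-out within the scatter. No supporting data are available to explain why these read-outs stay together.

Going by these compounds, whether a carboxylic acid or an amine in this place on the amide-type nitrogen would move the read-out beyond the scatter remains open. The single-concentration read-out also leaves the potency of all three compounds undefined.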